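The source may hold more compounds than are shown below. What is called first, only, known or untested is meant among the compounds shown, and "the series" means these compounds.

Measured compounds:
compound 1, `O=C(Nc1nn[nH]n1)c1cccc(Br)n1`: 48%
compound 2, `Cc1cccnc1C(=O)Nc1nn[nH]n1`: 69%

In a functional assay on the whole organism for inhibition, with Rattus norvegicus as the target, at a dose of 10 mg/kg by the oral route (on this read-out higher numbers stand for a stronger effect at the one dose given and lower numbers for a weaker effect), compound 1 gives 48%, the lowest of the two numbers. Compound 2 gives 69%, a number higher by a step beyond the usual scatter. Compound 3, `O=C(Nc1nn[nH]n1)c1cccc(Cl)n1`, has not yet been measured. It differs from compound 1 in one place: chloro in place of bromo on an aromatic carbon. Going by the values given here, no step between measured compounds shows what this kind of change does in this assay, so a change of little or no size is expected. The expected step of a number 3 percentage points lower from compound 1 to compound 3 (within the scatter) stays within the scatter. For compound 3 the estimate is 45%, with a range from 25% to 65%.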

Compound 3, a percentage reported as inhibition, in the whole organism at one dose (the size of the read-out at that dose, not a potency): 13%
Compound 3: the middle estimate sits 32 percentage points above what was measured; measured number outside the range, below it.
By their numbers in this assay, from the lowest: compound 3; then compound 1; then compound 2.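

In this assay, swapping one halogen for another at this place is far from neutral: chloro in place of bromo on an aromatic carbon brings a number 35 percentage points lower from compound 1 to compound 3 (beyond the scatter). This carbon, next to the ring nitrogen, is therefore sensitive to the exchange of a single heavy atom. Nothing available explains the drop.

From the compounds shown here alone, it remains open how other groups at this place, such as fluoro, an amine or a carboxylic acid, would compare with bromo and chloro. Going by these compounds, whether the same exchange has a similar effect on another core also remains open.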